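Changing the Ring on the Sulfonyl Sulfur

This account rests on a few compounds, and the source may have more. Where it says the series, first, only, none or still open, it means among the compounds named here.

Three measured compounds share one core and differ only in the aromatic ring attached to the sulfonyl sulfur. In a functional assay on KB cells (Homo sapiens) for antiproliferative activity, read by MTT assay, with a stated time of 72 h (a higher number here means a weaker inhibitor, a lower number a stronger inhibitor), compound 1 `CN(c1ccc2[nH]c(-c3n[nH]c4ccccc34)cc2n1)S(=O)(=O)c1ccc(Cl)cc1` gives 8350 nM. Compound 2 `COc1ccc(S(=O)(=O)N(C)c2ccc3[nH]c(-c4n[nH]c5ccccc45)cc3n2)c(OC)c1` gives 10200 nM in this assay, and compound 3 `CN(c1ccc2[nH]c(-c3n[nH]c4ccccc34)cc2n1)S(=O)(=O)c1cccc([N+](=O)[O-])c1` gives 5870 nM in this assay. Compound 3 has the lowest of the three numbers, but its distances to the others are small: a 1.4-fold lower number from compound 1 to compound 3 (0.15 log units; within the scatter) and a 1.7-fold lower number from compound 2 to compound 3 (0.24 log units; within the scatter), and the remaining pair shows a 1.2-fold higher number from compound 1 to compound 2 (0.09 log units; within the scatter). None of these three ring swaps moved the number beyond the scatter. Compound 4 `CN(c1ccc2[nH]c(-c3n[nH]c4ccccc34)cc2n1)S(=O)(=O)c1ccc(OC(F)(F)F)cc1` carries 4-(trifluoromethoxy)phenyl in place of 3-nitrophenyl on a sulfonyl sulfur. Since every exchange of the ring on this sulfur measured so far stayed within the scatter, the step from compound 3 to compound 4 is expected to be of that same small kind, a 1.2-fold higher number from compound 3 to compound 4 (0.08 log units; within the scatter). For compound 4 the estimated value in this assay is 7000 nM, expected to lie between 3500 nM and 14000 nM.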

Compound 4, half-maximal inhibitory concentration: 1330 nM
The estimate for compound 4 lay 5.3-fold (0.72 log units) above the measured number; measured number below the stated range.
By their numbers in this assay, from the lowest: compound 4; then compounds 3, 1 and 2 (each within the scatter of the next).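

Unlike the three earlier ring exchanges, this one shows that the group on the sulfonyl sulfur can move the number in this assay beyond the scatter (a 4.4-fold lower number from compound 3 to compound 4 (0.64 log units; beyond the scatter); a 7.7-fold lower number from compound 2 to compound 4 (0.88 log units; beyond the scatter)). The closest comparison keeps the phenyl ring and changes a single group on an aromatic carbon, trifluoromethoxy in place of chloro, and that alone gives a step beyond the scatter (a 6.3-fold lower number from compound 1 to compound 4 (0.80 log units; beyond the scatter)). Nothing available here explains why this exchange lowers the number.

The compounds shown leave open whether the result depends on the whole trifluoromethoxy group or on only part of it. A trifluoromethyl or plain methoxy group on the ring would help separate these possibilities, while an amine or a carboxylic acid would show how far different groups are tolerated.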